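The source may hold more compounds than are shown below. What is called first, only, known or untested is meant among the compounds shown, and "the series" means these compounds.

Two compounds share a core carrying a dimethylamino-substituted phenyl ring, an imidazolyl-substituted phenyl ring and a sulfonyl group. Compound 1 `CN(C)c1ccc(C2CC(c3ccc(-n4ccnc4)cc3)=NN2S(C)(=O)=O)cc1` carries a methyl on the sulfonyl sulfur, and in a functional assay on NCI-H1975 cells (Homo sapiens) for inhibition, read by sulforhodamine B assay, tested at 10 uM (a lower number here means less inhibition, a higher number more inhibition at the concentration tested (going by the name of the read-out)), compound 1 gives -3.8%. Compound 2 `Cc1ccc(S(=O)(=O)N2N=C(c3ccc(-n4ccnc4)cc3)CC2c2ccc(N(C)C)cc2)cc1` carries a 4-methylphenyl there instead, and in this assay compound 2 gives 50.5%. Going by the values given here, that single exchange is the only measured step, a number 54.3 percentage points higher from compound 1 to compound 2 (beyond the scatter), and it places compound 2 highest of the two numbers, with compound 1 as its only neighbour.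

Compound 3 `CN(C)c1ccc(C2CC(c3ccc(-n4ccnc4)cc3)=NN2S(=O)(=O)c2ccc([N+](=O)[O-])cc2)cc1` keeps the aryl sulfonyl of compound 2 but differs in one place: nitro in place of methyl on an aromatic carbon. Among the compounds with values here, no measured step swaps one substituent for another on that ring, so the step from methyl to 4-methylphenyl offers only indirect guidance. The step from compound 2 to compound 3 is therefore expected to be small, a number 5.5 percentage points lower from compound 2 to compound 3 (within the scatter), with either direction possible. Compound 3 is estimated to give 45% in this assay, within a range from 15% to 70%.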

Compound 3, a percentage reported as inhibition, at one concentration (the size of the read-out at that concentration, not a potency): 53%
The estimate for compound 3 lay 8 percentage points below the measured number; the range from low to high includes it.
By their numbers in this assay, from the lowest: compound 1; then compounds 2 and 3 (each within the scatter of the next).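

In this assay the step from methyl to nitro on the aromatic carbon para to a large group is small, a number 2.5 percentage points higher from compound 2 to compound 3 (within the scatter), so the two aryl sulfonyl compounds cannot be told apart at this position. The large step of a number 56.8 percentage points higher from compound 1 to compound 3 (beyond the scatter) shows that the change seen earlier, from methyl on the sulfonyl sulfur to an aryl ring, is not unique to 4-methylphenyl, since 4-nitrophenyl gives a similar step. Nothing available explains either result.

Still open, as far as these compounds go, is whether an amine or a carboxylic acid in that same ring place would also leave the number within the scatter of these two. Also open, from the compounds shown here alone, is how a plain unsubstituted phenyl, or a longer chain such as butyl, would behave on the sulfonyl sulfur.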